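Lengthening the alkyl chain on a hydroxyethyl-adenine series

The source may report more compounds than this note shows. Statements on the series, on what has been measured and on what is new or still open speak of the compounds shown alone.

Measured so far:
- compound 1, `CCCCCCCCC(CCO)n1cnc2c(N)ncnc21`: 20700 nM
- compound 2, `CCCCCCCCCCC(CCO)n1cnc2c(N)ncnc21`: 1200 nM

In a functional assay on SW480 cells (Homo sapiens) for antiproliferative activity, read by MTT assay, with a stated time of 48 h (on this read-out higher numbers stand for weaker inhibition and lower numbers for stronger inhibition), compound 1 gives 20700 nM, while compound 2 gives 1200 nM. Among the two measured compounds, compound 2 has the lowest number, and the only step recorded, a 17-fold lower number from compound 1 to compound 2 (1.24 log units; beyond the scatter), separates it clearly from compound 1. Compound 3, `CCCCCCCCCCCC(CCO)n1cnc2c(N)ncnc21`, has not yet been measured. Relative to compound 2 it differs by methyl in place of hydrogen on a saturated chain carbon, ten or more bonds along the chain from an aromatic nitrogen. Among the compounds with values here, the one step that bears on this change is the chain extension from compound 1 to compound 2, which was large; the present change is smaller, a single carbon rather than two, and sits one position further along the chain. A further decrease in the number is therefore expected for compound 3, though a more modest one. The step that this estimate for compound 3 means is an expected 2.4-fold lower number from compound 2 to compound 3 (0.38 log units; beyond the scatter). The estimate for compound 3 is 500 nM, within a range from 150 nM to 2000 nM.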

Compound 3, half-maximal inhibitory concentration: 11600 nM
Estimate against measurement, compound 3: 23-fold (1.37 log units) below, outside the stated range (above it).
By their numbers in this assay, from the lowest: compound 2; then compounds 3 and 1 (each within the scatter of the next).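

Adding one more methyl at this far end of the chain does not extend the earlier gain but reverses it: in this assay, the number rises with a 9.7-fold higher number from compound 2 to compound 3 (0.99 log units; beyond the scatter). The longest chain also gives no clear advantage over the shortest, since a 1.8-fold lower number from compound 1 to compound 3 (0.25 log units; within the scatter) leaves those two compounds indistinguishable, so compound 2 alone stands clearly lowest and the response to chain length among these three compounds is not steady. No measurement here explains why a single added methyl has so large an effect.

Three compounds cannot show whether compound 2 sits at a true optimum, or whether a longer chain would keep the number high or bring it down again. Nor do they show how the series would respond to an amine or a carboxylic acid in place of the hydroxyl.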